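The source may report more compounds than this note shows. Statements on the series, on what has been measured and on what is new or still open speak of the compounds shown alone.

Of the compounds shown here, three have so far been tested in a functional assay on OE21 cells (Homo sapiens) for cytotoxicity, read by MTT assay, with a stated time of 72 h; on this read-out higher numbers stand for weaker inhibition and lower numbers for stronger inhibition. Compound 1 `C=C(C)CCOc1ccc(C(C)=O)c(O)c1` gives > 100000 nM, which is a limit of the assay rather than a number (the limit of > 100000 nM in this assay, at which 1 of the 3 values shown sits). Compound 2 `COc1cc(/C=C/C=O)cc(OC)c1OC/C=C(\C)CCC=C(C)C` gives 27000 nM, the lowest of the two numbers measured. Compound 3 `CC(C)=CCOc1ccc(C(=O)/C=C/c2ccc(O)cc2)c(O)c1` gives 58000 nM, a higher number than compound 2 by more than the usual scatter. Compound 4 `COc1cc(/C=C/C=O)cc(OC)c1OCC=C(C)C` has not yet been measured; it differs from compound 2 in one place: hydrogen in place of 3-methylbut-2-en-1-yl on a saturated chain carbon bound to a double-bonded chain carbon. Within the data shown here, with no measured step of this kind to lean on, the change is expected to weaken inhibition only modestly, if at all beyond the scatter, giving a step of a 1.5-fold higher number from compound 2 to compound 4 (0.17 log units; within the scatter). Compound 4 is therefore estimated at 40000 nM, with a likely range from 15000 nM to 100000 nM.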

Compound 4, half-maximal inhibitory concentration: 29000 nM
Compound 4: the middle estimate sits 1.4-fold (0.14 log units) above what was measured; low and high end bracket the measured number.
By their numbers in this assay, from the lowest: compounds 2, 4 and 3 (each within the scatter of the next, the first and the last beyond it). At a limit, above all of these: compound 1.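

In this assay, putting hydrogen in place of 3-methylbut-2-en-1-yl on a saturated chain carbon bound to a double-bonded chain carbon gives a 1.1-fold higher number from compound 2 to compound 4 (0.03 log units; within the scatter), so compound 2 and compound 4 cannot be told apart. This first measured step at this position shows that the 3-methylbut-2-en-1-yl is not needed for the activity seen here. Nothing given explains this result.

Still open, from the compounds shown here alone, is whether a longer chain, an amine or a carboxylic acid at this position would give a number beyond the scatter.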